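A few compounds are considered here, and "the series" means these few. Any claim that something is new, unique, unknown or untested is made for them only; others in the source may bear on it.

Within the data shown here, compound 1 `COc1cc(-c2nnc(SCc3ccc(C)cc3)o2)ccc1O` stands lowest of the two numbers so far in a functional assay on cells (T-cell, Mus musculus, strain BALB/c) for inhibition, read by MTT assay, with stated times of 24 h and 72 h (on this read-out lower numbers stand for stronger inhibition and higher numbers for weaker inhibition), where compound 1 gives 6210 nM. Among the measured compounds shown here, its nearest neighbour is compound 2 `COc1cc(-c2nnc(SCc3ccc(F)cc3)o2)ccc1O`, which in this assay gives 8190 nM; the single step measured, a 1.3-fold higher number from compound 1 to compound 2 (0.12 log units; within the scatter), is within the scatter, so the two compounds cannot be ranked.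

Compound 3 `COc1cc(-c2nnc(SCc3ccc(C)cc3)o2)ccc1OCc1ccc(C)cc1` differs from compound 1 by 4-methylbenzyl in place of hydrogen on an oxygen on an aromatic ring. That measured step, with fluoro in place of methyl on an aromatic carbon, touches a different part of the molecule and says nothing about replacing the hydrogen on the oxygen with a group of eight carbon atoms. For the measured compounds named here, with no step of this kind available, the expectation is that compound 3 stays close to compound 1, with a wide range to cover the unknown: the estimated step of a 1.4-fold higher number from compound 1 to compound 3 (0.16 log units; within the scatter) is small. Compound 3 is therefore estimated at 9000 nM, between 2500 nM and 35000 nM.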

Compound 3, half-maximal inhibitory concentration: 9060 nM
Compound 3: middle estimate off by 1.0-fold (0.00 log units), on the low side; low and high end bracket the measured number.
By their numbers in this assay, from the lowest: compounds 1, 2 and 3 (each within the scatter of the next).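

Replacing the hydrogen on the oxygen on the aromatic ring with 4-methylbenzyl gives, in this assay, a 1.5-fold higher number from compound 1 to compound 3 (0.16 log units; within the scatter). The earlier step concerned only a fluoro or methyl on an aromatic carbon; this one shows that the hydroxy can become (4-methylbenzyl)oxy, gaining 8 heavy atoms and a six-membered aromatic ring, while compound 1 and compound 3 still cannot be ranked, so the hydroxy hydrogen is not needed for inhibition at this level. No measurement shown offers an explanation for this result.

On these data alone, whether a small methyl, a longer chain ending in an amine, or a carboxylic acid on this oxygen would behave the same stays open. So does whether any group here can move the number beyond the scatter.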